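The source may hold more compounds than are shown below. What is called first, only, known or untested is meant among the compounds shown, and "the series" means these compounds.

Compound 1 `Oc1ccc(OCc2ccc3ccccc3n2)cc1C1(c2ccccc2)CC2CCC1C2` carries a free hydroxy group on its aromatic ring. In a functional assay on blood (Homo sapiens) for inhibition (a lower number here means a stronger inhibitor, a higher number a weaker inhibitor), compound 1 gives 580 nM. Compound 2 `COC(=O)COc1ccc(OCc2ccc3ccccc3n2)cc1C1(c2ccccc2)CC2CCC1C2` is the same molecule with the hydroxy group capped: the change is (methoxycarbonyl)methyl in place of hydrogen on an oxygen on an aromatic ring, and it moved the number a 2.0-fold lower number from compound 1 to compound 2 (0.30 log units; within the scatter). In this assay compound 2 gives 290 nM. Compound 3 `Oc1ccc(OCc2ccc3ccccc3n2)cc1C1(c2ccccc2)CCCC1` keeps the free hydroxy group but has a different core; how the two cores differ is not broken down here. In this assay, among the measured compounds shown here, compound 3 gives 1920 nM, the highest of the three numbers so far. Compound 4 `COC(=O)COc1ccc(OCc2ccc3ccccc3n2)cc1C1(c2ccccc2)CCCC1` is yet to be measured. It stands to compound 3 exactly as compound 2 stands to compound 1, the change being (methoxycarbonyl)methyl in place of hydrogen on an oxygen on an aromatic ring at the same kind of place, so the two changes are the same. The step from compound 3 to compound 4 is expected to be a 1.9-fold lower number from compound 3 to compound 4 (0.28 log units; within the scatter), resting on the measured step of a 2.0-fold lower number from compound 1 to compound 2 (0.30 log units; within the scatter) in the matching pair. Compound 4 is therefore expected to give about 1000 nM, within a range of 500 nM to 2200 nM.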

Compound 4, half-maximal inhibitory concentration: 890 nM
Estimate against measurement, compound 4: 1.1-fold (0.05 log units) above; the measured number falls inside the stated range.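

In this assay, replacing the hydroxy group with (methoxycarbonyl)methoxy gives a 2.2-fold lower number from compound 3 to compound 4 (0.33 log units; beyond the scatter). Set beside the same change on the core of compound 1, the two steps match: the same change on two cores in this assay, a 2.0-fold lower number (0.30 log units; within the scatter) from compound 1 to compound 2 and a 2.2-fold lower number (0.33 log units; beyond the scatter) from compound 3 to compound 4, 1.1-fold (0.03 log units) apart, within the scatter of two such steps This shows that, on these two cores, the change carries over at about the same modest size, but two pairs cannot show that it would do so on a third core, nor do they explain why the number moves.

On these data alone, it remains open whether the step depends on the whole (methoxycarbonyl)methyl group or would also appear with any group placed on that oxygen. The compounds shown do not tell how the matching carboxylic acid, a plain methyl group or a longer chain ending in the same ester would behave on either core.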